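This account rests on a few compounds, and the source may have more. Where it says the series, first, only, none or still open, it means among the compounds named here.

Measured so far in an assay on isolated protein for inhibition of cathepsin S (Homo sapiens); on this read-out lower numbers stand for stronger inhibition and higher numbers for weaker inhibition:
- compound 1 `COc1ccc2[nH]cc(C3CCN(CC(O)Cn4nc(-c5ccc(C(F)(F)F)cc5)c5c4CCN(S(C)(=O)=O)C5)CC3)c2c1` gives 29 nM
- compound 2 `CS(=O)(=O)N1CCc2c(c(-c3ccc(C(F)(F)F)cc3)nn2CC(O)CN2CCC(c3c[nH]c4ccc(C#N)cc34)CC2)C1` gives 21 nM
- compound 3 `CS(=O)(=O)N1CCc2c(c(-c3ccc(C(F)(F)F)cc3)nn2CC(O)CN2CCC(c3c[nH]c4cccnc34)CC2)C1` gives 120 nM

Compound 3 stands highest of the three numbers in this assay: the nearest is compound 1 (a 4.1-fold higher number from compound 1 to compound 3 (0.62 log units; beyond the scatter)), the furthest is compound 2 (a 5.7-fold higher number from compound 2 to compound 3 (0.76 log units; beyond the scatter)). Compounds 1 and 2 lie within the scatter of each other (a 1.4-fold lower number from compound 1 to compound 2 (0.14 log units; within the scatter)).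

Compound 4 `CS(=O)(=O)N1CCc2c(c(-c3ccc(C(F)(F)F)cc3)nn2CC(O)CN2CCC(c3c[nH]c4ccncc34)CC2)C1` differs from compound 3 in one place: a group of 9 heavy atoms (7 carbon, 2 nitrogen; one five-membered aromatic ring with 1 hetero atom, one six-membered aromatic ring with 1 hetero atom) in place of a group of 9 heavy atoms (7 carbon, 2 nitrogen; one five-membered aromatic ring with 1 hetero atom, one six-membered aromatic ring with 1 hetero atom), on a saturated ring carbon. The two have the same atoms, joined differently. Among the compounds with values here, none of the measured steps bears directly on this change: the steps into compound 3 swapped a six-membered aromatic ring of carbon only for one with 1 hetero atom, whereas here the ring with 1 hetero atom is kept and only its arrangement changes. There is therefore no basis in the numbers for a direction, and the step in this assay is expected to be none beyond the scatter, with a wider uncertainty than usual.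

Compound 4 is estimated at 120 nM, range 40 nM to 360 nM, meaning an expected step of no change at the digits printed from compound 3 to compound 4 (within the scatter).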

Compound 4, half-maximal inhibitory concentration: 58 nM
For compound 4 the middle estimate is 2.1-fold (0.32 log units) above the measured one, within the range that was stated.
By their numbers in this assay, from the lowest: compounds 2, 1 and 4 (each within the scatter of the next, the first and the last beyond it); then compound 3.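

At this saturated ring carbon, the arrangement of the same atoms within the group registers on its own in this assay: a 2.1-fold lower number from compound 3 to compound 4 (0.32 log units; beyond the scatter). The presence of a hetero atom in the six-membered aromatic ring is therefore not the only thing that counts here, as the two groups with identical counts do not give the same number. Against the carbon-only rings, the comparison is a 2.8-fold higher number from compound 2 to compound 4 (0.44 log units; beyond the scatter) for the cyano-bearing group and a 2.0-fold higher number from compound 1 to compound 4 (0.30 log units; within the scatter) for the methoxy-bearing group, so compound 4 sits clear of compound 2 but is not separated from compound 1, and no evidence available here accounts for any of this.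

Still open, going by these compounds, is whether other arrangements of the ring nitrogen would move the number further. Also open, on these data alone, is what an amine or a carboxylic acid on the six-membered aromatic ring would do in place of the cyano group.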